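Formyl to hydroxymethyl on a compound at the limit

The compounds below may be only part of what the source reports. "The series", "measured", "known", "first", "only" and "open" are said of these compounds alone.

Compound 1 `CC1(C)O[C@@H]2CC[C@](C)(O)[C@H](CCC3C(C=O)=CCC4C(CC[C@@]4(C)O)C3(C)C)[C@@]2(C)CCC1=O`: > 50000 nM (a limit)
Compound 2 `CC1(C)C(CC[C@@H]2[C@@]3(C)CC[C@@H](O)C(C)(C)O[C@@H]3CC[C@]2(C)O)C(C=O)=CCC2C1CC[C@@]2(C)O`: > 50000 nM (a limit)

In a functional assay on KB-C2 cells (Homo sapiens) for cytotoxicity, read by MTT assay, with a stated time of 68 h (on this read-out lower numbers stand for stronger inhibition and higher numbers for weaker inhibition), compound 1 gives > 50000 nM, which is a limit and not a number. Compound 2 also gives a limit, > 50000 nM, and the two together make up (the limit of > 50000 nM in this assay, at which 2 of the 2 values shown sit). Compound 3 `CC1(C)O[C@@H]2CC[C@](C)(O)[C@H](CCC3C(CO)=CCC4C(CC[C@@]4(C)O)C3(C)C)[C@@]2(C)CCC1=O` keeps the core of compound 1 and changes one group: hydroxymethyl in place of formyl on a double-bonded ring carbon. In plain terms, it has hydroxymethyl in place of formyl on a double-bonded ring carbon. Among the measured compounds shown here, no measured pair shows what this swap does, so the expectation rests on compound 1 alone. No step beyond the usual scatter is expected in this assay, in either direction. The estimated change is a number no higher from compound 1 to compound 3 (the limit leaves the size open). Compound 3 is expected at about 50000 nM, with an estimated range from 20000 nM to 100000 nM.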

Compound 3, half-maximal inhibitory concentration: > 50000 nM
Compound 3: only a limit was reported (the forecaster's own chance of this, stated with the estimate: 70%); the middle value sits exactly at the limit.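

Compound 1 and compound 3 both give only a limit in this assay, so no step can be read for hydroxymethyl in place of formyl: the limit of > 50000 nM in this assay, at which 3 of the 3 values shown sit.

The compounds shown leave open whether this swap changes the cytotoxicity at all, and what change to the shared core would give a measurable number.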